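The compounds below may be only part of what the source reports. "The series", "measured", "known", "first", "only" and "open" are said of these compounds alone.

Measured in an ADME assay on microsomes from liver (Homo sapiens) for metabolic stability, read by LC-MS, using NADPH, with a stated time of 10 min, tested at 10 uM; on this read-out lower numbers stand for a shorter-lived compound and higher numbers for a longer-lived compound:
- compound 1 `N#Cc1ccnc(Oc2nn([C@H]3C[C@H](O)C3)c3ncnc(N)c23)c1`: > 2.41 h
- compound 2 `Nc1ncnc2c1c(Oc1cccc(C(F)(F)F)c1)nn2[C@H]1C[C@H](O)C1`: 1.25 h

Compound 1 stands at the limit of > 2.41 h in this assay, at which 1 of the 2 values shown sits, so its entry is a limit of the assay and not a number. Compound 2 gives a plain number, 1.25 h.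

The open question is compound 3 `N#Cc1ccnc(Oc2nn([C@H]3C[C@@H](O)C3)c3ncnc(N)c23)c1`. Its difference from compound 1 is the two compounds have the same atoms and bonds and differ only in configuration as drawn: 2 of 2 stereo elements differ (all stereocentres are inverted: mirror images); a stereocentre at a saturated ring carbon is drawn r in compound 1 and s in compound 3; a stereocentre at a saturated ring carbon is drawn r in compound 1 and s in compound 3. No atoms leave or enter, and only the configuration as drawn changes at the saturated ring carbons.

Within the data shown here, no measured pair isolates a change of configuration, so the expectation in this assay is no shift beyond the scatter, with no direction favoured. The starting point for that expectation is compound 1 at > 2.41 h, again a limit. The expected step is a step that the limit leaves unreadable from compound 1 to compound 3. Compound 3 is estimated at 2.5 h, with an expected range from 1.2 h to 5 h.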

Compound 3, half-life: > 2.41 h
Compound 3: only a limit was reported; the forecaster's own chance of this, stated with the estimate: 55%; the middle value is on the limit's open side.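

No step can be read between compound 1 and compound 3, since both entries are limits of the assay and not numbers: the limit of > 2.41 h in this assay, at which 2 of the 3 values shown sit.

The compounds shown leave open whether inverting the configuration at the saturated ring carbons shifts the half-life at all.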